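The source may hold more compounds than are shown below. What is called first, only, known or untested is meant among the compounds shown, and "the series" means these compounds.

In a physicochemical assay for lipophilicity, at pH 7.4 (on this read-out lower numbers stand for lower lipophilicity and higher numbers for higher lipophilicity), compound 1 (`CNC(=O)c1cc(C)n(Cc2cc(Cl)ccc2OCc2ccccc2)n1`) gives > 3.7, which is a limit and not a number. Compound 2 (`Cc1cc(C(=O)Nc2ccccc2)nn1Cc1cc(Cl)ccc1OCc1ccccc1`) gives > 3.7, also a limit. Compound 3 (`Cc1cc(NC(=O)C(C)C)nn1Cc1cc(Cl)ccc1OCc1ccccc1`) gives > 3.7, again a limit. Within the data shown here, the series so far therefore offers only (the limit of > 3.7 in this assay, at which 3 of the 3 values shown sit). Compound 4 (`Cc1cc(NC(=O)C2CCOCC2)nn1Cc1cc(Cl)ccc1OCc1ccccc1`) differs from compound 3 by oxan-4-yl in place of isopropyl on a carbonyl carbon, with oxan-4-yl in place of isopropyl on a carbonyl carbon. The nearest measured steps, a step that the two limits leave unreadable from compound 1 to compound 3 and a step that the two limits leave unreadable from compound 2 to compound 3, give no size to carry over, and a step that the two limits leave unreadable from compound 1 to compound 2 gives none either. The expectation in this assay thus rests on the structural change alone, with its entering hydrogen-bond acceptor. The expected move is toward lower numbers, estimated as a number at least 0.30 log units lower from compound 3 to compound 4 (that floor lies within the scatter). Compound 4 is estimated at 3.4, within a range of 2.9 to 3.9.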

Compound 4, distribution coefficient: > 3.7
Compound 4 was reported as a limit; the forecaster's own chance of this, stated with the estimate: 35%; middle value at least 0.30 log units from the limit.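

In this assay compound 4 gives > 3.7, a limit, and its steps from compound 1, compound 2 and compound 3 cannot be read. From the compounds shown here alone, whether oxan-4-yl in place of isopropyl on a carbonyl carbon changes the read-out at all stays open.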